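The source may hold more compounds than are shown below. What is called first, only, known or untested is meant among the compounds shown, and "the series" means these compounds.

Measured in an ADME assay on MDBK cells (Bos taurus) for cytotoxicity, read by MTT assay, with a stated time of 96 h; a higher number here means that more compound is tolerated, a lower number that less compound is tolerated:
Compound 1 `COc1ccc(-c2nc3cc([N+](=O)[O-])ccc3[nH]2)c(OC)c1OC`: > 100000 nM
Compound 2 `COc1ccc(-c2nc3cc(C(C)=O)ccc3[nH]2)c(OC)c1`: > 100000 nM

Each of these entries is a limit, not a number. The measured set therefore comes down to the limit of > 100000 nM in this assay, at which 2 of the 2 values shown sit. Compound 2 stands at that same limit, and no numerical value is available for it. For the measured compounds named here, no step between measured compounds is available, so the data give no size for any structural change.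

Compound 3 `COc1ccc(-c2nc3cc(C(C)=O)ccc3[nH]2)c(OC)c1OC` differs from compound 2 by a single change: methoxy in place of hydrogen on an aromatic carbon. The methoxy stands in place of hydrogen on an aromatic carbon, ortho to two methoxy groups and meta to a large group.

Compound 2 gives > 100000 nM, a limit, and this is the only basis for the expectation. No change beyond the usual scatter is expected, and neither direction is favoured. The most likely report for compound 3 is again a limit. The expected step of a number no higher from compound 2 to compound 3 (the limit leaves the size open) is none beyond the scatter. The estimate for compound 3 is 100000 nM, with an expected range of 50000 nM to 200000 nM.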

Compound 3, half-maximal cytotoxic concentration: > 100000 nM
Compound 3: no number, only a limit (the forecaster's own chance of this, stated with the estimate: 85%); the middle value lies on the limit itself.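

Compound 3 is again reported only as a limit, so neither step, from compound 2 to compound 3 or from compound 1 to compound 3, can be read in this assay: the limit of > 100000 nM in this assay, at which 3 of the 3 values shown sit.

The compounds shown leave open what half-maximal cytotoxic concentration compound 1, compound 2 and compound 3 actually have, and whether methoxy in place of hydrogen or acetyl in place of nitro alters it.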